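The source may hold more compounds than are shown below. What is called first, only, known or untested is meant among the compounds shown, and "the series" means these compounds.

Two relatives with the same core have been tested so far in a functional assay on WRL68 cells (Homo sapiens) for cytotoxicity, read by MTT assay, with a stated time of 4 h (a higher number here means a weaker inhibitor, a lower number a stronger inhibitor), and they give different kinds of result. Compound 1 (`COC(=O)C1=CO[C@@H](O[C@@H]2O[C@H](COC(c3ccccc3)(c3ccccc3)c3ccccc3)[C@@H](OC(=O)O)[C@H](OC(C)=O)[C@H]2OC(C)=O)[C@@H]2[C@@H](C)[C@@H](OC(C)=O)C[C@H]12`) gives 2.44 ug/mL as its half-maximal inhibitory concentration. Compound 2 (`COC(=O)C1=CO[C@@H](O[C@@H]2O[C@H](CO)[C@@H](OC(C)=O)[C@H](OC(C)=O)[C@H]2OC(C)=O)[C@@H]2[C@@H](C)[C@@H](OC(C)=O)C[C@H]12`) is recorded as "not active" (no number reported) with no number, so it has no place on the numerical scale and offers no figure to start from.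

Compound 3 (`CCC(=O)OC[C@H]1O[C@@H](O[C@@H]2OC=C(C(=O)OC)[C@H]3C[C@H](OC(C)=O)[C@H](C)[C@@H]23)[C@H](OC(C)=O)[C@@H](OC(C)=O)[C@@H]1OC(C)=O`) is compound 2 with one change: propanoyl in place of hydrogen on an oxygen on a saturated carbon. In plainer terms, a propanoyl takes the place of a hydrogen on an oxygen on a saturated carbon, turning hydroxymethyl into (propanoyloxy)methyl.

For the measured compounds named here, no measured pair shows this change, so the size of the step in this assay cannot be read from the data. The expected direction is modest: from no number for compound 2 towards a measurable but fairly weak inhibitor, with a real chance of no number again. The value of compound 1 at 2.44 ug/mL is the only numerical anchor, and compound 3 is expected to sit on the weaker side of it.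

Compound 3 is estimated at about 12 ug/mL with an expected range from 3 ug/mL to 50 ug/mL in this read-out.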

Compound 3, half-maximal inhibitory concentration: 2.65 ug/mL
Compound 3: middle estimate off by 4.5-fold (0.66 log units), on the high side; measured number outside the range, below it.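

For the compounds shown here, compound 2 carries no number and compound 3 gives 2.65 ug/mL, which leaves no step between them to read. No measurement shown here bears on the reason for this result. The compounds shown leave open how large the effect of swapping hydroxymethyl for (propanoyloxy)methyl is, and how other groups in that place would behave.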